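The source may hold more compounds than are shown below. What is called first, only, known or untested is meant among the compounds shown, and "the series" means these compounds.

Compound 1 `Cc1ccc(-c2nc(N)c3cc(C(C)c4ccccc4)sc3n2)o1`: 439 nM
Compound 2 `Nc1nc(-c2ccc(C(F)F)o2)nc2sc(Cc3ccccc3)cc12`: 3000 nM
Compound 3 `COc1ccccc1Cc1cc2c(N)nc(-c3cccc(C#N)c3)nc2s1`: 129 nM

These three compounds share one core and were tested in a functional assay on CHO-K1 cells for antagonist activity at adenosine receptor A1 (Homo sapiens), read by a beta-galactosidase reporter and cAMP accumulation, with stated times of 15 min and 6 h; a lower number here means a stronger inhibitor, a higher number a weaker inhibitor. Compound 2 gives the highest number of the three, so it is the weakest inhibitor here; compound 1 gives a lower number, and compound 3 a lower number still, both gaps lying beyond the usual scatter. Compound 4 `N#Cc1cncc(-c2nc(N)c3cc(Cc4ccccc4)sc3n2)c1` is not yet measured. Its structure differs from compound 2 in one place: 5-cyanopyridin-3-yl in place of 5-(difluoromethyl)furan-2-yl on an aromatic carbon. Among the measured compounds shown here, no measured pair shows this exact change, so the size of the step in this assay must be estimated rather than read off. Compound 3, which also carries a nitrile-bearing aromatic ring at this position, gives 129 nM, which suggests a step downward, beyond the scatter. Compound 4 is therefore expected to give 350 nM, in a range from 90 nM to 1400 nM, an estimated step of an 8.6-fold lower number from compound 2 to compound 4 (0.93 log units; beyond the scatter).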

Compound 4, inhibition constant: 1160 nM
For compound 4 the middle estimate is 3.3-fold (0.52 log units) below the measured one, within the range that was stated.
By their numbers in this assay, from the lowest: compound 3; then compound 1; then compound 4; then compound 2.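

On the aromatic carbon between two ring nitrogen atoms, putting 5-cyanopyridin-3-yl in place of 5-(difluoromethyl)furan-2-yl gives in this assay a 2.6-fold lower number from compound 2 to compound 4 (0.41 log units; beyond the scatter) and so a modest gain in inhibition. Among the compounds shown here, this is the first direct evidence that changing the aromatic group at this position alone shifts the inhibition, since the earlier compounds all differed in more than one place. Nothing measured here explains the step. Going by these compounds, it remains open how an unsubstituted phenyl or an aminopyridine would compare at this position, and whether this swap gives a similar step on compounds with other groups elsewhere on the shared core.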